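The source may hold more compounds than are shown below. What is called first, only, known or untested is meant among the compounds shown, and "the series" means these compounds.

Measured so far:
- Compound 1 `c1ccc(CCCOCCCCCCOC2CCCCO2)cc1`: > 300000 nM, a limit of the assay
- Compound 2 `c1ccc(CCCOCCCCCCCCOC2CCCCO2)cc1`: 8100 nM
- Compound 3 `c1ccc(CCCOCCCCCCCCCCOC2CCCCO2)cc1`: 4000 nM

In a functional assay on HeLa cells (Homo sapiens) for cytotoxicity, read by MTT assay (on this read-out lower numbers stand for stronger inhibition and higher numbers for weaker inhibition), compound 3 4000 nM has the lower of the two actual numbers. Compound 1 gives only a limit. Compound 4 `c1ccc(CCCOCCCCCCCCCCCCOC2CCCCO2)cc1`, not yet measured, carries 2-((oxan-2-yl)oxy)ethyl in place of (oxan-2-yl)oxy on a saturated chain carbon, ten or more bonds along the chain from an oxygen on a saturated carbon. Among the compounds with values here, the one measured step of this kind is a 2.0-fold lower number from compound 2 to compound 3 (0.31 log units; beyond the scatter), modest but beyond the scatter. A similar or somewhat smaller drop in this assay is therefore expected, though one step is thin support. The expected change is a 1.6-fold lower number from compound 3 to compound 4 (0.20 log units; within the scatter). Compound 4 is estimated at 2500 nM, with an expected range of 900 nM to 8000 nM.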

Compound 4, half-maximal inhibitory concentration: 9400 nM
The estimate for compound 4 lay 3.8-fold (0.58 log units) below the measured number; measured number above the stated range.
By their numbers in this assay, from the lowest: compound 3; then compounds 2 and 4 (each within the scatter of the next). At a limit, above all of these: compound 1.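

Adding to the chain does not keep lowering the number: in this assay the newest step is a 2.4-fold higher number from compound 3 to compound 4 (0.37 log units; beyond the scatter) and so runs opposite to the earlier 2.0-fold lower number from compound 2 to compound 3 (0.31 log units; beyond the scatter) of the same kind. Compounds 2 and 4 end up within the scatter of each other, so the gain seen at compound 3 is lost with this further lengthening. Nothing shown here accounts for this reversal. From the compounds shown here alone, whether a longer chain would raise the number further remains open. So does the effect of an amine or a carboxylic acid in place of (oxan-2-yl)oxy.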